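Swapping fluoro for hydroxy in a small series

The source may hold more compounds than are shown below. What is called first, only, known or untested is meant among the compounds shown, and "the series" means these compounds.

In a functional assay on SW982 cells (Homo sapiens) for inhibition, read by MTT assay, with a stated time of 72 h (on this read-out lower numbers stand for stronger inhibition and higher numbers for weaker inhibition), compound 3 (`COc1cc(OC)c(OC)cc1/C=C/C(=O)c1ccc(F)cc1`) gives 32500 nM and stands level with compound 1 (`COc1cc(OC)c(OC)cc1/C=C/C(=O)c1ccc(Cl)cc1`) at 58500 nM in this comparison, since a 1.8-fold lower number from compound 1 to compound 3 (0.26 log units; within the scatter) stays within the scatter. Compound 2 (`COc1cc(OC)c(OC)cc1/C=C/C(=O)c1ccccc1`) shows only a limit of the assay, > 150000 nM and no exact number. Compound 4 (`COc1cc(OC)c(OC)cc1/C=C/C(=O)c1ccc(O)cc1`) carries hydroxy in place of fluoro on an aromatic carbon is the change. Among the compounds with values here, no measured step tests hydroxy. The closest guides are an at least 4.6-fold lower number from compound 2 to compound 3 (0.66 log units; beyond the scatter) and an at least 2.5-fold higher number from compound 1 to compound 2 (0.40 log units; beyond the scatter) as steps, showing only that a hydrogen here gives a higher number than either halogen. The expected step is a 1.4-fold higher number from compound 3 to compound 4 (0.14 log units; within the scatter) and probably stays within the scatter. Compound 4 is estimated at 45000 nM within a range of 15000 nM to 140000 nM in this assay here.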

Compound 4, half-maximal inhibitory concentration: 155000 nM
Compound 4: the middle estimate sits 3.4-fold (0.54 log units) below what was measured; the measured number lies above the stated range.
By their numbers in this assay, from the lowest: compounds 3 and 1 (each within the scatter of the next); then compound 4.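

In this assay, a substituent at this position does not by itself give a low number, as swapping a halogen for hydroxy raises it: a 4.8-fold higher number from compound 3 to compound 4 (0.68 log units; beyond the scatter), and a 2.6-fold higher number from compound 1 to compound 4 (0.42 log units; beyond the scatter). Until now, only hydrogen had been seen to fall short of the halogens, and hydroxy now does too. The step from compound 2 to compound 4 cannot be read, because compound 2 gives only a limit: the limit of > 150000 nM in this assay, at which 1 of the 4 values shown sits.

On these data alone, it remains open whether an amine or a carboxylic acid here would sit with the halogens or with hydroxy. Bromo is also untested among the compounds shown, so the halogen trend rests on fluoro and chloro alone.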